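The compounds below may be only part of what the source reports. "The series", "measured", "known", "first", "only" and "open" are said of these compounds alone.

Measured compounds:
compound 1 `O=C(CCCCC1CCSS1)NCc1cn(CCCCOc2ccc3cc(-c4ccccc4)c(=O)oc3c2)nn1`: 34.8%
compound 2 `O=C(CCCCC1CCSS1)NCc1cn(CCCCOc2ccc3cc(-c4ccc(Cl)cc4)c(=O)oc3c2)nn1`: 46.2%
compound 3 `O=C(CCCCC1CCSS1)NCc1cn(CCCCCOc2ccc3cc(-c4ccccc4)c(=O)oc3c2)nn1`: 30.7%

In a functional assay on PC-12 cells (Rattus norvegicus) for cytotoxicity, read by MTT assay, with stated times of 3 h and 2 h, tested at 1 uM (a higher number here means a stronger effect of the compound at the concentration tested, a lower number a weaker effect), compound 3 gives the lowest of the three numbers, though compound 1 sits within the scatter of it; only compound 2 lies beyond. Compound 4 `O=C(CCCCC1CCSS1)NCc1cn(CCCCCOc2ccc3cc(-c4ccc(Cl)c(Cl)c4)c(=O)oc3c2)nn1` differs from compound 3 by 3,4-dichlorophenyl in place of phenyl on an aromatic carbon. Within the data shown here, the one measured step that bears on this is a number 11.4 percentage points higher from compound 1 to compound 2 (beyond the scatter), a single chloro on the same ring of the shared core. Among the measured compounds shown here, the change to compound 4 goes further, bringing the 3,4-dichlorophenyl, so a rise in this assay of at least that size is expected, perhaps somewhat larger, with no direct precedent for the second substituent. Compound 4 is therefore estimated at 45%, within 32% to 60%. This corresponds to an expected step of a number 14.3 percentage points higher from compound 3 to compound 4 (beyond the scatter).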

Compound 4, a percentage reported as activity, at one concentration (the size of the read-out at that concentration, not a potency): 50.6%
Beside the measured number, compound 4's estimate is 5.6 percentage points below it; low and high end bracket the measured number.
By their numbers in this assay, from the lowest: compounds 3 and 1 (each within the scatter of the next); then compounds 2 and 4 (each within the scatter of the next).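

In this assay, the rise seen with chlorine on this phenyl ring is not confined to the chain of compound 1: 3,4-dichlorophenyl in place of phenyl gives a number 19.9 percentage points higher from compound 3 to compound 4 (beyond the scatter) on the chain of compound 3. The earlier step, a number 11.4 percentage points higher from compound 1 to compound 2 (beyond the scatter), came from a single chloro on the other chain, so these two steps cannot separate the effect of the second chloro from that of the chain. Nothing available here accounts for either rise.

Open, as far as these compounds go, is whether a single chloro on the chain of compound 3 already gives most of this step. Also open, from the compounds shown here alone, is whether fluoro, methoxy or an amine at this ring would raise the number as chloro does.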